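This account rests on a few compounds, and the source may have more. Where it says the series, first, only, none or still open, it means among the compounds named here.

Three compounds of the series share one core and differ only in the group on the amine nitrogen. Compound 1 `Cc1ccc(S(=O)(=O)/N=C(/CCNC2=CC(=O)c3ccccc3C2=O)Nc2ccc(Cl)cc2)cc1` carries 4-chlorophenyl there; in an ADME assay on HEK293 cells (Homo sapiens) for cytotoxicity, read by MTT assay, with a stated time of 48 h (a lower number here means a stronger inhibitor, a higher number a weaker inhibitor), compound 1 gives 65400 nM. Compound 2 `COc1cc(N/C(CCNC2=CC(=O)c3ccccc3C2=O)=N\S(=O)(=O)c2ccc(C)cc2)cc(OC)c1OC` carries 3,4,5-trimethoxyphenyl, and in this assay compound 2 gives 75800 nM. Compound 3 `Cc1ccc(S(=O)(=O)/N=C(/CCNC2=CC(=O)c3ccccc3C2=O)NC(C)C)cc1` carries isopropyl; in this assay compound 3 gives 71600 nM. Compound 3 stands second highest of the three numbers, but every step among them lies within the scatter: a 1.2-fold higher number from compound 1 to compound 2 (0.06 log units; within the scatter), a 1.1-fold higher number from compound 1 to compound 3 (0.04 log units; within the scatter) and a 1.1-fold lower number from compound 2 to compound 3 (0.02 log units; within the scatter). The three numbers therefore read as one level, with no ordering claimed among them.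

Compound 4 `Cc1ccc(S(=O)(=O)/N=C(/CCNC2=CC(=O)c3ccccc3C2=O)NCc2ccccc2)cc1` is not yet measured. The change from compound 3 is benzyl in place of isopropyl on an amine nitrogen. Going by the values given here, no measured step exchanges isopropyl for benzyl. The exchanges at this nitrogen that were measured, between 4-chlorophenyl and 3,4,5-trimethoxyphenyl and between either of them and isopropyl, all stayed within the scatter, and a benzyl group on the same nitrogen is expected to do the same. The expected step of a 1.0-fold lower number from compound 3 to compound 4 (0.01 log units; within the scatter) is thus no step beyond the scatter in this assay. Compound 4 is expected to give 70000 nM in this assay, with a range from 35000 nM to 140000 nM.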

Compound 4, half-maximal inhibitory concentration: 80200 nM
For compound 4 the middle estimate is 1.1-fold (0.06 log units) below the measured one, within the range that was stated.
By their numbers in this assay, from the lowest: compounds 1, 3, 2 and 4 (each within the scatter of the next).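

In this assay, going by these compounds alone, the exchange of isopropyl for benzyl on this amine nitrogen enlarges the group from 3 to 7 heavy atoms and adds a six-membered aromatic ring of carbon only, yet it gives a 1.1-fold higher number from compound 3 to compound 4 (0.05 log units; within the scatter) and leaves the number at the level of the earlier compounds. The same reading holds against the two phenyl groups, with benzyl in place of 3,4,5-trimethoxyphenyl giving a 1.1-fold higher number from compound 2 to compound 4 (0.02 log units; within the scatter) and benzyl in place of 4-chlorophenyl giving a 1.2-fold higher number from compound 1 to compound 4 (0.09 log units; within the scatter), so four groups on this nitrogen, a ring-free one, two directly attached phenyl groups and now benzyl, all read as one level with no ordering among them. No data at hand offer an explanation for this flat reading.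

Still open, going by these compounds, is whether a carboxylic acid, a primary amine or a longer chain ending in either, placed on this nitrogen, would stay at the same level. Also open, on these data alone, is whether the level moves at all when a change is made in the shared core rather than on this nitrogen.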